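This account rests on a few compounds, and the source may have more. Where it says the series, first, only, none or still open, it means among the compounds named here.

In a functional assay on CWR22R cells (Homo sapiens) for antiproliferative activity, read by MTT assay, with a stated time of 3 days (a lower number here means a stronger inhibitor, a higher number a weaker inhibitor), compound 1 `COc1cc(O)c2c(=O)cc(-c3ccc(NS(=O)(=O)C4CC4)cc3)oc2c1OC(C)C` gives 19700 nM, while compound 2 `COc1cc(O)c2c(=O)cc(-c3ccc(NC(=O)NC4CC4)cc3)oc2c1OC(C)C` gives 6700 nM, the lower of the two numbers. Compound 3 `COc1cc(O)c2c(=O)cc(-c3ccc(NC(=O)N4CCNCC4)cc3)oc2c1OC(C)C` carries piperazin-1-yl in place of cyclopropylamino on a carbonyl carbon. Among the measured compounds shown here, the only measured step, a 2.9-fold lower number from compound 1 to compound 2 (0.47 log units; beyond the scatter), is modest and came from a different swap, cyclopropylcarbamoyl in place of cyclopropylsulfonyl, so it gives a rough size and no direction for this change. A step beyond the scatter is therefore not expected, and the estimate is a 1.1-fold lower number from compound 2 to compound 3 (0.05 log units; within the scatter). For compound 3 the estimated value is 6000 nM, with an expected range of 2000 nM to 20000 nM.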

Compound 3, half-maximal inhibitory concentration: 1300 nM
The estimate for compound 3 lay 4.6-fold (0.66 log units) above the measured number, and the stated range ends above it.
By their numbers in this assay, from the lowest: compound 3; then compound 2; then compound 1.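

In this assay, changing only the group on the carbonyl carbon moves the number beyond the scatter (a 5.2-fold lower number from compound 2 to compound 3 (0.71 log units; beyond the scatter)), so this position is sensitive to the swap from cyclopropylamino to piperazin-1-yl. Measured against the cyclopropylsulfonyl group on the nitrogen, the full change gives a large step (a 15-fold lower number from compound 1 to compound 3 (1.18 log units; beyond the scatter)). No evidence at hand accounts for this gain. Still open, on these data alone, is whether morpholin-4-yl or 4-methylpiperazin-1-yl on the same carbonyl carbon would match compound 3.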